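A few compounds are considered here, and "the series" means these few. Any claim that something is new, unique, unknown or untested is made for them only; others in the source may bear on it.

Compound 1 `CC(C)Cc1nn(-c2cccc(F)c2)cc1C(=O)NCc1ccccc1` is one of three compounds examined in a toxicity assay on HepG2 2.2.15 cells (Homo sapiens) for cytotoxicity, read by CCK-8 assay, with a stated time of 8 days; on this read-out lower numbers stand for higher toxicity in this test and higher numbers for lower toxicity in this test. In this assay compound 1 gives 85900 nM, the highest of the three numbers. Compound 3 `CCOC(=O)c1cn(-c2ccc(OC)cc2)nc1CC(C)C` gives 77100 nM, which lies within the scatter of compound 1, so the two cannot be told apart on this read-out. Compound 2 `CCOC(=O)c1cn(-c2ccccc2[N+](=O)[O-])nc1CC(C)C` gives 4850 nM, a number that lies beyond the scatter below compound 1, so compound 2 is clearly the more toxic of those two. Within the data shown here, no two of the measured compounds differ in a single place, so no step between measured compounds can be read off.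

Compound 4 `CC(C)Cc1nn(-c2cccc(F)c2)cc1C(=O)NNc1ccc(F)cc1` has not yet been measured in this assay. It differs from compound 1 in one place: (4-fluorophenyl)amino in place of benzyl on an amide-type nitrogen. Among the measured compounds shown here, nothing among the measured compounds shows what such a change does in this assay, and the esters compound 2 and compound 3 differ from compound 1 in more than one place. The step from compound 1 to compound 4 is therefore expected to be a 1.4-fold lower number from compound 1 to compound 4 (0.16 log units; within the scatter), a small move towards higher toxicity that may well fall within the scatter. For compound 4 the expected value in this assay is 60000 nM, with a range from 20000 nM to 150000 nM.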

Compound 4, half-maximal cytotoxic concentration: 45400 nM
Beside the measured number, compound 4's estimate is 1.3-fold (0.12 log units) above it; measured number inside the range.
By their numbers in this assay, from the lowest: compound 2; then compounds 4, 3 and 1 (each within the scatter of the next).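

Among these compounds, this is the first step that can be read at this place on the amide-type nitrogen: in this assay the change to (4-fluorophenyl)amino from benzyl gives a 1.9-fold lower number from compound 1 to compound 4 (0.28 log units; within the scatter) and so leaves the two compounds indistinguishable on this read-out. The swap is not a small one in what it brings in, since it adds a nitrogen, a fluorine and a hydrogen-bond donor while keeping a six-membered aromatic ring, yet on this single pair the read-out does not separate the two groups. The data shown offer no explanation for this result.

The compounds shown leave open what the added nitrogen and the fluorine each do on their own, which a phenylamino group or a fluorobenzyl group on the same nitrogen would help to separate. They also leave open whether this place would stay as undiscriminating with no aromatic ring at all, as with a cyclohexyl group or a short ethyl chain, or with a carboxylic acid or an amine carried on that group.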